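The compounds below may be only part of what the source reports. "The series", "measured", "known", "first", "only" and "open" are said of these compounds alone.

Measured so far:
- Compound 1, `Fc1cccc(F)c1-c1nc2cc(C(F)(F)F)ccc2[nH]1`, in an ADME assay on MDBK cells (Bos taurus) for cytotoxicity, read by MTT assay, with a stated time of 96 h; a higher number here means that more compound is tolerated, a lower number that less compound is tolerated: >= 100000 nM
- Compound 2, `O=[N+]([O-])c1ccc(-c2nc3cc(Cl)c(Cl)cc3[nH]2)cc1`, in this assay: compound 2 gives 56000 nM

Compound 1 sits at a limit of the assay and not at a number: its reading of >= 100000 nM stops at the limit of >= 100000 nM in this assay, at which 1 of the 2 values shown sits. Compound 2 therefore stands as the only true number among the two results shown, with compound 1 sitting at a limit rather than at a measured point.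

The next compound, compound 3, is `Nc1ccc(-c2nc3cc(Cl)c(Cl)cc3[nH]2)cc1`. It keeps the whole of compound 2 except that (amino in place of nitro on an aromatic carbon). Nothing measured here tells how such a swap of amino for nitro moves the half-maximal cytotoxic concentration, so no direction can be drawn from the data. The step is expected to stay small, a 1.1-fold higher number from compound 2 to compound 3 (0.03 log units; within the scatter), within the usual scatter of repeated measurements, with a fair chance that the result is again reported only as a limit. Compound 3 is expected to give about 60000 nM, most likely between 25000 nM and 100000 nM.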

Compound 3, half-maximal cytotoxic concentration: 7500 nM
Compound 3: the middle estimate sits 8.0-fold (0.90 log units) above what was measured; the whole stated range lies above it.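

With compound 3, the series gains its first step between two compounds that differ in one place: in this assay, amino in place of nitro on an aromatic carbon, para to a large group, gives a 7.5-fold lower number from compound 2 to compound 3 (0.87 log units; beyond the scatter), and this step lies beyond the usual scatter. Compound 2 alone could not show whether the group at this position matters for how much compound is tolerated, and this pair shows that it does, with less tolerated when amino stands there than when nitro does. No measurement here gives a reason for the step, so it remains an observation on a single pair of compounds.

On these data alone, what remains open is whether the step is particular to amino and nitro, or whether a methoxy group, a carboxylic acid or an acetamide at the same place would give a number near either compound. Also open, as far as these compounds go, is whether the same swap would act alike on another core, such as that of compound 1, which differs from both other compounds in more than one place and whose reading is only a limit.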